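Trifluoromethyl in place of methoxy: what to expect

The compounds below may be only part of what the source reports. "The series", "measured", "known", "first", "only" and "open" are said of these compounds alone.

Compound 1 `COc1c(-c2ccccc2)oc2ccc(NC(C)=O)cc2c1=O`: 200000 nM
Compound 2 `COc1ccc(-c2oc3ccc(NC(C)=O)cc3c(=O)c2OC)cc1`: 369000 nM

In an ADME assay on MT4 cells (Homo sapiens) for cytotoxicity, read by MTT assay, with a stated time of 4 days (on this read-out higher numbers stand for lower toxicity in this test and lower numbers for higher toxicity in this test), compound 1 gives 200000 nM and compound 2 gives 369000 nM. Within the data shown here, these are the only two numbers so far, and they lie within the usual scatter of each other, so compound 2 stands level with compound 1.

The next compound, compound 3 `COc1c(-c2ccc(C(F)(F)F)cc2)oc2ccc(NC(C)=O)cc2c1=O`, has not been measured yet. It carries trifluoromethyl in place of methoxy on an aromatic carbon.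

Among the measured compounds shown here, only one measured step bears on this change, and it involves the methoxy group that compound 3 gives up: a 1.8-fold higher number from compound 1 to compound 2 (0.27 log units; within the scatter). Methoxy in place of hydrogen thus moved the number no further than the scatter. For the measured compounds named here, no measured compound carries trifluoromethyl, so this evidence is thin.

In this assay I therefore expect no step beyond the scatter, with only a slight, uncertain lean towards a lower number. The expected step is a 1.5-fold lower number from compound 2 to compound 3 (0.17 log units; within the scatter). For compound 3 the estimated value is 250000 nM, with an expected range from 100000 nM to 500000 nM.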

Compound 3, half-maximal cytotoxic concentration: 332000 nM
For compound 3 the middle estimate is 1.3-fold (0.12 log units) below the measured one, within the range that was stated.
By their numbers in this assay, from the lowest: compounds 1, 3 and 2 (each within the scatter of the next).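

In this assay trifluoromethyl in place of methoxy gives a 1.1-fold lower number from compound 2 to compound 3 (0.05 log units; within the scatter) and trifluoromethyl in place of hydrogen gives a 1.7-fold higher number from compound 1 to compound 3 (0.22 log units; within the scatter) so hydrogen, methoxy and trifluoromethyl on this aromatic carbon, para to a large group, all stand level. The earlier pair showed this only for methoxy against hydrogen, whereas now a group of 4 heavy atoms with 0 hydrogen-bond acceptors replaces one of 2 heavy atoms with 1 hydrogen-bond acceptor, and the read-out still does not separate the compounds. No measurement shown here offers an explanation for this flat result.

From the compounds shown here alone, what remains open is whether a very different group on this same carbon, such as an amine, a carboxylic acid or a longer chain, would move the number beyond the scatter. These three compounds also leave open whether changes elsewhere on the shared core would do so, and whether the same level picture would hold on any read-out other than this one.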